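The compounds below may be only part of what the source reports. "The series", "measured", "known", "first", "only" and "open" are said of these compounds alone.

Measured compounds:
compound 1, `CCCCCCCC(C)OC(=O)NC(=O)Nc1c(C(C)C)cccc1C(C)C`: 390 nM
compound 2, `CCCCCCCCC(C)OC(=O)NC(=O)Nc1c(C(C)C)cccc1C(C)C`: 750 nM
compound 3, `CCCCCCCCCCCOC(=O)NC(=O)Oc1c(C(C)C)cccc1C(C)C`: 140 nM

All three values come from an assay on microsomes from intestine for inhibition of acyl-CoA:cholesterol acyltransferase (Oryctolagus cuniculus); on this read-out lower numbers stand for stronger inhibition and higher numbers for weaker inhibition. Compound 1 carries the carbamoyl urea core; compound 2 differs from it by methyl in place of hydrogen on a saturated chain carbon, eight bonds along the chain from an oxygen next to a carbonyl group, and the step of a 1.9-fold higher number from compound 1 to compound 2 (0.28 log units; within the scatter). Compound 3 is built on a different core; the difference between the two cores is not broken down here. Among the measured compounds, compound 3 gives the lowest number in this assay.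

Compound 4, `CCCCCCCCCCCCOC(=O)NC(=O)Oc1c(C(C)C)cccc1C(C)C`, has not been measured. It differs from compound 3 by methyl in place of hydrogen on a saturated chain carbon, ten or more bonds along the chain from an oxygen next to a carbonyl group. This is the same kind of change as from compound 1 to compound 2, but not at the same place on the chain. Because the earlier step of a 1.9-fold higher number from compound 1 to compound 2 (0.28 log units; within the scatter) stayed within the scatter, a similar small step, a 1.4-fold higher number from compound 3 to compound 4 (0.13 log units; within the scatter), is expected here. For compound 4 the estimated value in this assay is 190 nM, with a likely span from 70 nM to 500 nM.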

Compound 4, half-maximal inhibitory concentration: 21 nM
Beside the measured number, compound 4's estimate is 9.0-fold (0.96 log units) above it, and the stated range ends above it.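

In this assay, methyl in place of hydrogen on a saturated chain carbon, ten or more bonds along the chain from an oxygen next to a carbonyl group, gives a 6.7-fold lower number from compound 3 to compound 4 (0.82 log units; beyond the scatter). The same kind of change does not carry over between the two cores at a fixed size: the same change on two cores in this assay, a 1.9-fold higher number (0.28 log units; within the scatter) from compound 1 to compound 2 and a 6.7-fold lower number (0.82 log units; beyond the scatter) from compound 3 to compound 4, 13-fold (1.11 log units) apart, beyond the scatter of two such steps. This does not separate the core from the place on the chain, as the earlier step sits eight bonds along the chain, and one pair per core shows no trend.

Still open, going by these compounds, is whether a longer chain on the core of compound 3 would extend this step or reverse it. Also open, on these data alone, is how the same change behaves at one matched place on both cores.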